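This account rests on a few compounds, and the source may have more. Where it says the series, first, only, none or still open, it means among the compounds named here.

Working notes on the series. Three compounds share a common core and differ only in the group carried on the five-membered aromatic ring. Compound 1 `NS(=O)(=O)c1cc(-c2nnc(CN3CCN(Cc4ccccc4)CC3)o2)c(Cl)cc1SCc1ccccc1` in a functional assay on HeLa cells (Homo sapiens) for cytotoxicity, read by MTT assay, with a stated time of 72 h (a higher number here means a weaker inhibitor, a lower number a stronger inhibitor), gives 17000 nM. Compound 2 `CCOC(=O)c1cn(Cc2nnc(-c3cc(S(N)(=O)=O)c(SCc4ccccc4)cc3Cl)o2)nn1` gives 122000 nM, the highest of the three numbers; its nearest neighbour is compound 3 `NS(=O)(=O)c1cc(-c2nnc(CNC(=O)c3ccccc3)o2)c(Cl)cc1SCc1ccccc1`, which gives 105000 nM, and its furthest is compound 1, whose number is lower by a margin beyond the scatter. Among the compounds with values here, the only single-point step measured so far, a 1.2-fold lower number from compound 2 to compound 3 (0.07 log units; within the scatter), exchanges the group on the saturated chain carbon and leaves the number essentially where it was.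

Compound 4 `NS(=O)(=O)c1cc(-c2nnc(/C=C/c3cccc(Cl)c3)o2)c(Cl)cc1SCc1ccccc1` is not yet measured. Relative to compound 2 the change is 2-(3-chlorophenyl)ethenyl in place of (4-(ethoxycarbonyl)-1H-1,2,3-triazol-1-yl)methyl on an aromatic carbon. Within the data shown here, no measured step matches this exchange: the step from compound 2 to compound 3 shows that swapping one pendant group for another on the chain carbon can stay within the scatter, while the values of compound 2 and compound 1 show that a different group at this position can come with a much lower number. Among the measured compounds shown here, the expectation for compound 4 is therefore a moderately lower number, a 2.0-fold lower number from compound 2 to compound 4 (0.31 log units; beyond the scatter), with no confidence that the step clears the scatter. Compound 4 is estimated at 60000 nM, with a range from 20000 nM to 180000 nM.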

Compound 4, half-maximal inhibitory concentration: 16000 nM
For compound 4 the middle estimate is 3.8-fold (0.57 log units) above the measured one, and the stated range ends above it.
By their numbers in this assay, from the lowest: compounds 4 and 1 (each within the scatter of the next); then compounds 3 and 2 (each within the scatter of the next).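

In this assay, within the data shown here, the group on the aromatic carbon of the five-membered ring can carry a step beyond the scatter without any nitrogen or oxygen in it: 2-(3-chlorophenyl)ethenyl gives a 7.6-fold lower number from compound 2 to compound 4 (0.88 log units; beyond the scatter) and a 6.6-fold lower number from compound 3 to compound 4 (0.82 log units; beyond the scatter), so the result holds against two different starting groups, where the one earlier single-point step stayed within the scatter. Compound 4 gives 16000 nM and compound 1 gives 17000 nM, values within the scatter of each other, so two unlike groups, one with only carbon and chlorine and the other bearing a benzyl-substituted piperazine on its methyl, share this level among the four compounds. No measured data bear on why the change has this size.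

The compounds shown do not separate the contributions of the chlorine, the double bond and the aromatic ring within 2-(3-chlorophenyl)ethenyl; a plain 2-phenylethenyl group and a saturated 2-(3-chlorophenyl)ethyl chain would address that directly. On these data alone, it also remains open how the number responds to a group of a different kind at this position, such as a carboxylic acid or a free amine on the chain carbon.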